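This account rests on a few compounds, and the source may have more. Where it says the series, first, only, none or still open, it means among the compounds named here.

In an in vitro ADME assay on microsomes from liver (Homo sapiens) for metabolic stability, using NADPH (on this read-out lower numbers stand for slow clearance and higher numbers for fast clearance), compound 1 `COc1ccc(Cl)cc1Cn1c(C(=O)NCC(C)(C)CO)cc2cc(C#N)ccc21` gives 83 mL.min-1.g-1 and compound 2 `Cc1ccc(Cl)cc1Cn1c(C(=O)NCC(C)(C)CO)cc2cc(C#N)ccc21` gives 119 mL.min-1.g-1 on the same scale. These two numbers lie within the scatter of each other, so compound 2 stands level with compound 1. Compound 3 `CCCOc1cccc(Cn2c(C(=O)NCC(C)(C)CO)cc3cc(C#N)ccc32)c1` has 3-propoxyphenyl in place of 5-chloro-2-methylphenyl on a saturated chain carbon bound to an aromatic nitrogen. Going by the values given here, the only measured step is a 1.4-fold higher number from compound 1 to compound 2 (0.16 log units; within the scatter) and it lies within the scatter. That step is methyl in place of methoxy on an aromatic carbon, a far smaller swap than this one, so it is only a weak guide. With so little evidence, no step beyond the scatter is expected in this assay and no direction can be favoured. The expected step is a 1.1-fold higher number from compound 2 to compound 3 (0.02 log units; within the scatter) and the range is kept wide. For compound 3 the estimated value is 125 mL.min-1.g-1 with an expected range from 60 mL.min-1.g-1 to 260 mL.min-1.g-1.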

Compound 3, intrinsic clearance in microsomes: 156 mL.min-1.g-1
Estimate against measurement, compound 3: 1.2-fold (0.10 log units) below; the range from low to high includes it.
By their numbers in this assay, from the lowest: compounds 1, 2 and 3 (each within the scatter of the next).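

In this assay, 3-propoxyphenyl in place of 5-chloro-2-methylphenyl on a saturated chain carbon bound to an aromatic nitrogen gives a 1.3-fold higher number from compound 2 to compound 3 (0.12 log units; within the scatter), and the same group in place of 5-chloro-2-methoxyphenyl gives a 1.9-fold higher number from compound 1 to compound 3 (0.27 log units; within the scatter). Both steps lie within the scatter, so all three compounds stand level even though this swap replaces the whole substituted phenyl group, a far larger change than methyl for methoxy. Nothing available here explains this result or separates the effect of one part of the swap from another.

Going by these compounds, all three compounds carry a substituted phenyl group at this place, so it remains open whether an amine or a carboxylic acid on that ring would move clearance beyond the scatter. On these data alone, it also remains open what the propoxy chain and the chlorine each contribute, since one leaves as the other enters.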